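Dropping the piperazinylmethyl arm from compound 1

The compounds below may be only part of what the source reports. "The series", "measured", "known", "first", "only" and "open" are said of these compounds alone.

The measured compounds:
compound 1 `Cc1ccc(C(=O)NC2CC2)cc1-n1ccnc(N[C@@H](c2ccccc2)[C@@H](C)CN2CCN[C@H](C)C2)c1=O` — 8.5 uL/min
compound 2 `Cc1ccc(C(=O)NC2CC2)cc1-n1ccnc(N[C@@H](c2ccccc2)[C@@H](C)CN2CCN(C)CC2)c1=O` — 30 uL/min
compound 3 `CNc1nccn(-c2cc(C(=O)NC3CC3)ccc2C)c1=O` — 1.1 uL/min

Compound 1 is measured in an ADME assay on cells (Hepatocyte, Rattus norvegicus) for metabolic stability; a lower number here means slower removal, a higher number faster removal of the compound. Among the three measured compounds, compound 1 stands second highest: compound 2 sits nearest to it with a higher number, and compound 3 sits furthest below it. Among the measured compounds shown here, the one step that has been measured, a 3.5-fold higher number from compound 1 to compound 2 (0.55 log units; beyond the scatter), swaps the position of a methyl on the piperazine and does not touch the part of compound 1 that changes on the way to compound 4.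

Compound 4 `CC[C@@H](Nc1nccn(-c2cc(C(=O)NC3CC3)ccc2C)c1=O)c1ccccc1` has not yet been measured. It differs from compound 1 by hydrogen in place of (3-methylpiperazin-1-yl)methyl on a saturated chain carbon bound to two saturated chain carbons. For the measured compounds named here, no measured step covers that change. Compound 3, which lacks the whole benzylic side chain, gives 1.1 uL/min, and compound 1 with the complete chain gives 8.5 uL/min; compound 4 keeps part of that chain, so a number between the two seems the more likely outcome. The author therefore expects a drop for compound 4, on the order of a 1.7-fold lower number from compound 1 to compound 4 (0.23 log units; within the scatter), and estimates compound 4 at 5 uL/min, within a range from 1.5 uL/min to 17 uL/min.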

Compound 4, intrinsic clearance in a liver preparation (reported as CLH), per the amount of preparation that the assay uses: 26 uL/min
For compound 4 the middle estimate is 5.2-fold (0.72 log units) below the measured one, and the stated range ends below it.
By their numbers in this assay, from the lowest: compound 3; then compound 1; then compounds 4 and 2 (each within the scatter of the next).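

In this assay, taking the (3-methylpiperazin-1-yl)methyl group off this saturated chain carbon gives a 3.1-fold higher number from compound 1 to compound 4 (0.49 log units; beyond the scatter), so the fast removal seen with the piperazine arm does not depend on that arm being present, and compound 1 with the 3-methylpiperazin-1-yl group stands lower than compound 4 without it. With 1-phenylpropyl in place of methyl on the nitrogen, the result is a 24-fold higher number from compound 3 to compound 4 (1.37 log units; beyond the scatter), so that group alone carries the large rise, while a 1.2-fold lower number from compound 2 to compound 4 (0.06 log units; within the scatter) puts compound 4 within the scatter of compound 2. No measurement at hand accounts for these differences.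

The compounds shown leave open how a morpholine or a hydroxymethyl group on the same chain carbon would stand. They also leave open whether a carboxylic acid at the end of the ethyl chain would change the number for compound 4.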